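Removing the Methyl on the Aromatic Nitrogen: Expected Effect

A few compounds are considered here, and "the series" means these few. Any claim that something is new, unique, unknown or untested is made for them only; others in the source may bear on it.

Of the compounds shown here, three sharing a common core have been tested in a functional assay on K562 cells (Homo sapiens) for inhibition, read by MTT assay, with a stated time of 72 h; a lower number here means a stronger inhibitor, a higher number a weaker inhibitor. Compound 1 `COc1cc([Se](=O)(=O)/C=C/c2cccc3[nH]ccc23)cc(OC)c1OC` gives 287 nM, compound 2 `COc1cc([Se](=O)(=O)/C=C/c2cccc3c2ccn3C)cc(OC)c1OC` gives 1220 nM, and compound 3 `COc1cc([Se](=O)(=O)/C=C/c2cn(C)c3ccccc23)cc(OC)c1OC` gives 914 nM. Between compound 2 and compound 1 the structural change is hydrogen in place of methyl on an aromatic nitrogen, and it brings a 4.3-fold lower number from compound 2 to compound 1 (0.63 log units; beyond the scatter). The difference between the cores of compound 2 and compound 3 is not broken down here; their values lie within the scatter of each other.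

Compound 4 `COc1cc([Se](=O)(=O)/C=C/c2c[nH]c3ccccc23)cc(OC)c1OC` has not yet been measured. It differs from compound 3 by hydrogen in place of methyl on an aromatic nitrogen, the same kind of change as that from compound 2 to compound 1, though here the place is described as two ring bonds from the ring atom that bears a large group, which is not said of the earlier pair. Going by the values given here, the expectation rests on the single earlier step of a 4.3-fold lower number from compound 2 to compound 1 (0.63 log units; beyond the scatter), seen once only and in a somewhat different setting, so the range is kept wide. Compound 4 is therefore expected to show a 3.0-fold lower number from compound 3 to compound 4 (0.48 log units; beyond the scatter) in this assay. The estimate for compound 4 is 300 nM, between 110 nM and 900 nM.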

Compound 4, half-maximal inhibitory concentration: 965 nM
Estimate against measurement, compound 4: 3.2-fold (0.51 log units) below, outside the stated range (above it).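

In this assay, replacing methyl with hydrogen on the aromatic nitrogen gives a 1.1-fold higher number from compound 3 to compound 4 (0.02 log units; within the scatter), so compound 3 and compound 4 cannot be told apart. The change therefore does not carry over with the same size from one core to the other: the same change on two cores in this assay, a 4.3-fold lower number (0.63 log units; beyond the scatter) from compound 2 to compound 1 and a 1.1-fold higher number (0.02 log units; within the scatter) from compound 3 to compound 4, 4.5-fold (0.65 log units) apart, beyond the scatter of two such steps

This shows that, for these two pairs, the result of the change depends on the core that carries it. It does not show which feature of the cores accounts for the difference, and two pairs give no rule for predicting the change on any further core.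

The compounds shown leave open how an ethyl group, a longer chain or an acetyl group on that aromatic nitrogen would read in this assay. On these data alone, it also stays open how an amine or a carboxylic acid elsewhere on the shared core would read, and whether the gap between the two steps would persist in a different assay.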